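A few compounds are considered here, and "the series" means these few. Any claim that something is new, unique, unknown or untested is made for them only; others in the source may bear on it.

This account follows the step from compound 2 to compound 4 in a functional assay on SMMC-7721 cells (Homo sapiens) for cytotoxicity, read by MTT assay, with a stated time of 4 days; a lower number here means a stronger inhibitor, a higher number a weaker inhibitor. Of the compounds shown here, three have been measured so far, and none gave a number. Compound 1 `COc1ccc(-c2cn(C[C@H]3c4c(ccc(O)c4C)[C@@H]4CC[C@@]5(C)C[C@]43CC5=O)nn2)cc1` gives in this assay a value of > 20000 nM, which is a limit of the assay rather than a number. Compound 2 `C=C1C[C@]23C[C@@]1(O)CC[C@H]2c1cc(Br)c(O)c(C)c1[C@@H]3Cn1cc(-c2ccc(C)cc2)nn1` gives in this assay a value of > 20000 nM, again a limit and not a number. Compound 3 `C=C1C[C@]23C[C@@]1(O)CC[C@H]2c1ccc(OS(=O)(=O)c2ccc(C)cc2)c(C)c1[C@@H]3Cn1cc(-c2ccc(C)cc2)nn1` gives in this assay a value of > 20000 nM, also a limit. Compound 2 therefore stands where every measured compound stands, at the limit of > 20000 nM in this assay, at which 3 of the 3 values shown sit. Going by the values given here, no measured pair differs in only one place, so no step between measured compounds can be read from these data.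

Compound 4 `C=C1C[C@]23C[C@@]1(O)CC[C@H]2c1cc(Br)c(O)c(C)c1[C@@H]3Cn1cc(-c2ccccc2)nn1` has not yet been measured in this assay. It differs from compound 2 in one place: hydrogen in place of methyl on an aromatic carbon. The expectation rests on the limit alone. A change from 4-methylphenyl to phenyl is expected to shift the value by no more than the usual scatter, so the step that the limit leaves unreadable from compound 2 to compound 4 is expected to be small, with no clear direction. Compound 4 is accordingly estimated at 25000 nM in this assay, with a range from 10000 nM to 60000 nM, and the assay is expected most likely to report only a limit once more.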

Compound 4, half-maximal inhibitory concentration: > 20000 nM
Compound 4: no number, only a limit; the forecaster's own chance of this, stated with the estimate: 85%; the middle value is on the limit's open side.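

Going by these compounds alone, compound 2 and compound 4 each reach only a limit in this assay, not a number, so no step between them can be read. The compounds shown leave open whether replacing 4-methylphenyl with phenyl changes cytotoxicity at all, and which of these structures would give a number, as every value sits at one limit: the limit of > 20000 nM in this assay, at which 4 of the 4 values shown sit.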